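Extending the linker chain of a cyanoguanidine cytotoxic series

The source may report more compounds than this note shows. Statements on the series, on what has been measured and on what is new or still open speak of the compounds shown alone.

Of the compounds shown here, two have been tested in a functional assay on HONE1 cells for cytotoxicity against HONE1 cell line (Homo sapiens); on this read-out lower numbers stand for stronger inhibition and higher numbers for weaker inhibition. Compound 1 `CC1C(=O)N(CCCCCCCOc2ccc(Cl)cc2)/C(=N\C#N)N1c1ccncc1` gives 371 nM, and compound 2 `N#C/N=C1\N(CCCCCCOc2ccc(Cl)cc2)C(=O)C(c2ccccc2)N1c1ccncc1` gives 337 nM. These two numbers lie within the scatter of each other, so neither can be called more potent. Compound 3 `N#C/N=C1\N(CCCCCCCOc2ccc(Cl)cc2)C(=O)C(c2ccccc2)N1c1ccncc1` differs from compound 2 only by (4-chlorophenoxy)methyl in place of 4-chlorophenoxy on a saturated chain carbon, six bonds along the chain from an amide-type nitrogen in a ring, a one-carbon lengthening of the chain. Going by the values given here, no measured pair shows this exact step, so no step beyond the scatter is expected. Compound 3 is therefore estimated at 340 nM in this assay, with a range from 170 nM to 700 nM, a step of a 1.0-fold higher number from compound 2 to compound 3 (0.00 log units; within the scatter).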

Compound 3, half-maximal inhibitory concentration: 398 nM
The estimate for compound 3 lay 1.2-fold (0.07 log units) below the measured number; measured number inside the range.
By their numbers in this assay, from the lowest: compounds 2, 1 and 3 (each within the scatter of the next).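

In this assay, the one-carbon lengthening, with (4-chlorophenoxy)methyl in place of 4-chlorophenoxy on the chain, gives a 1.2-fold higher number from compound 2 to compound 3 (0.07 log units; within the scatter) and so has no readable effect at this position. Phenyl in place of methyl on a saturated ring carbon gives a 1.1-fold higher number from compound 1 to compound 3 (0.03 log units; within the scatter) and is likewise unreadable, so with the longer chain these two groups cannot be told apart here.

Going by these compounds, whether a still longer chain, such as one ending in 4-(4-chlorophenoxy)butyl, or an amine at the chain end would shift the number remains open. Nothing available explains why these changes leave the numbers so close.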